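A few compounds are considered here, and "the series" means these few. Any claim that something is new, unique, unknown or untested is made for them only; others in the source may bear on it.

Measured so far:
compound 1, `C/C(=N\Nc1nc(-c2ccc(C)cc2)cs1)c1cc2ccccc2o1`: 21400 nM
compound 2, `C/C(=N\Nc1nc(-c2ccccc2)cs1)c1cc2ccccc2o1`: 16700 nM

In a functional assay on PC-3 cells (Homo sapiens) for antiproliferative activity (on this read-out lower numbers stand for stronger inhibition and higher numbers for weaker inhibition), compound 1 stands highest of the two numbers, with compound 2 nearest to it. Within the data shown here, the only measured step, a 1.3-fold lower number from compound 1 to compound 2 (0.11 log units; within the scatter), concerns a different change, so nothing measured speaks directly to the replacement ahead. Compound 3, `C/C(=N\Nc1nc(-c2cc3ccccc3o2)cs1)c1cc2ccccc2o1`, differs from compound 1 by 1-benzofuran-2-yl in place of 4-methylphenyl on an aromatic carbon. Among the measured compounds shown here, with no measured step bearing on this change, the expected step of a 1.3-fold lower number from compound 1 to compound 3 (0.13 log units; within the scatter) is none beyond the scatter, carrying a wide range. Compound 3 is expected to give 16000 nM, between 4000 nM and 60000 nM.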

Compound 3, half-maximal inhibitory concentration: 34200 nM
Compound 3: the middle estimate sits 2.1-fold (0.33 log units) below what was measured; measured number inside the range.
By their numbers in this assay, from the lowest: compounds 2, 1 and 3 (each within the scatter of the next, the first and the last beyond it).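

In this assay, 1-benzofuran-2-yl on this aromatic carbon of the thiazole-free description aside, the shared core takes the larger two-ring group with only a small shift: measured against 4-methylphenyl, the swap gives a 1.6-fold higher number from compound 1 to compound 3 (0.20 log units; within the scatter), and measured against phenyl it gives a 2.0-fold higher number from compound 2 to compound 3 (0.31 log units; beyond the scatter). So this two-ring group brings no stronger inhibition, and against phenyl the number moves modestly the weaker way. No measurement on hand explains this shift. From the compounds shown here alone, what stays open is whether an amine or a carboxylic acid at this position would lower the number, and whether any group here can reach much stronger inhibition.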